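Notes on a chloro to methyl exchange

The source may hold more compounds than are shown below. What is called first, only, known or untested is meant among the compounds shown, and "the series" means these compounds.

Measured so far in a functional assay on OVCAR-3 cells (Homo sapiens) for antiproliferative activity, read by spectrophotometry, with a stated time of 2 days; on this read-out higher numbers stand for weaker inhibition of growth and lower numbers for stronger inhibition of growth:
- compound 1 `COc1cc(N2CCN(C(C)=O)CC2)ccc1Nc1ncc(C(F)(F)F)c(N2Cc3cccc(N(C)S(C)(=O)=O)c3C2)n1` gives 1600 nM
- compound 2 `Cc1ccc(Nc2ncc(C(F)(F)F)c(N3Cc4cccc(N(C)S(C)(=O)=O)c4C3)n2)c(Cl)c1` gives > 30000 nM
- compound 3 `CN(c1cccc2c1CN(c1nc(Nc3ccc(Nc4ccccc4)cc3)ncc1C(F)(F)F)C2)S(C)(=O)=O` gives > 50000 nM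

Compound 2 stands at a limit (> 30000 nM) and has no number. Compound 3 also stands at a limit (> 50000 nM). Only compound 1 gives a number, and no two of the three compounds differ in one place alone.

Compound 4 (`Cc1ccc(Nc2ncc(C(F)(F)F)c(N3Cc4cccc(N(C)S(C)(=O)=O)c4C3)n2)c(C)c1`) differs from compound 2 in one place: 2-chloro-4-methylphenyl becomes 2,4-dimethylphenyl, with methyl in place of chloro on an aromatic carbon, ortho to a large group and meta to a methyl group (methyl in place of chloro on an aromatic carbon). Within the data shown here, no measured pair shows this exchange. In this assay no step beyond the scatter is expected, and the data give no direction. The estimated change is a step that the limit leaves unreadable from compound 2 to compound 4 and it is expected to stay small. This expectation rests on compound 2 (> 30000 nM), whose value is a limit. A report of compound 4 as a limit alone is also expected to be likely. Compound 4 is estimated at 35000 nM with an expected range of 12000 nM to 100000 nM as its span.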

Compound 4, concentration for 50% growth inhibition: > 30000 nM
Compound 4: no number, only a limit; the forecaster's own chance of this, stated with the estimate: 65%; the middle value is on the limit's open side.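

Compound 2 and compound 4 both stand at a limit in this assay, so no step between them can be read: the limit of > 30000 nM in this assay, at which 2 of the 4 values shown sit.

Still open, as far as these compounds go, is whether methyl in place of chloro on an aromatic carbon changes growth inhibition at all; neither compound gives a number.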